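The compounds below may be only part of what the source reports. "The series", "measured", "known", "first", "only" and "open" are said of these compounds alone.

Compound 1 `O=C(Nc1ccc(N2CCOCC2=O)cc1)c1ccc2[nH]c(-c3ccc(Cl)s3)nc2c1`: in an assay on isolated protein for binding affinity to Trypsin (Homo sapiens) (on this read-out lower numbers stand for stronger inhibition and higher numbers for weaker inhibition), compound 1 gives only the assay limit > 10000 nM.
Compound 2 `Cc1cc(NC(=O)CCc2ccc3[nH]c(-c4ccc(Cl)s4)nc3c2)ccc1N1CCOCC1=O`: in this assay compound 2 gives only the assay limit > 10000 nM.

Compound 2 thus stands at the limit of this assay, where both shown values sit (the limit of > 10000 nM in this assay, at which 2 of the 2 values shown sit); no number is known for it, and no step between measured compounds can be stated. Compound 3 `O=C(CCc1ccc2[nH]c(-c3ccc(Cl)s3)nc2c1)Nc1ccc(N2CCOCC2=O)cc1` differs from compound 2 by hydrogen in place of methyl on an aromatic carbon. With both measured compounds at the limit, the step that the limit leaves unreadable from compound 2 to compound 3 is expected to stay within the scatter. Compound 3 is estimated at 20000 nM, range 5000 nM to 100000 nM, most likely reported again only as a limit.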

Compound 3, half-maximal inhibitory concentration: > 10000 nM
Compound 3 gave a limit, no number (the forecaster's own chance of this, stated with the estimate: 85%); the middle value does not contradict the limit.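

Within the data shown here, compound 2 and compound 3 both give only a limit in this assay, so no step between them can be read: the limit of > 10000 nM in this assay, at which 3 of the 3 values shown sit. Whether the methyl group affects inhibition, and what number any of these compounds would give, remains open.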